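The source may hold more compounds than are shown below. What is called first, only, known or untested is meant among the compounds shown, and "the series" means these compounds.

Measured so far:
- compound 1 `CC(C)c1onc(-c2c(Cl)cccc2Cl)c1COc1ccc(-c2nc3ccc(C(=O)O)cc3n2CC2CC2)cc1` — 19.4 nM
- compound 2 `CCC(CC)n1c(-c2ccc(OCc3c(-c4c(Cl)cccc4Cl)noc3C(C)C)cc2F)nc2ccc(C(=O)O)cc21` — 1.3 nM

Among the compounds with values here, in an assay on Huh-7 cells for agonist activity at Bile acid receptor (Homo sapiens), read by a luciferase reporter (a higher number here means that more compound is needed for the effect, a lower number that less compound is needed), compound 1 gives 19.4 nM, the highest of the two numbers known. Within the data shown here, compound 2 gives 1.3 nM, a gap beyond the scatter, but compound 2 differs from compound 1 in more than one place, so no single step between measured compounds can be read from the pair.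

Compound 3 `CC(C)c1onc(-c2c(Cl)cccc2Cl)c1COc1ccc(-c2nc3ccc(C(=O)O)cc3n2C2CCCCCC2)cc1` is not yet measured. The change from compound 1 is cycloheptyl in place of cyclopropylmethyl on an aromatic nitrogen.

Among the measured compounds shown here, for this step the only guide is that the larger branched group on the ring nitrogen of compound 2 goes with its lower number of 1.3 nM; on that basis a moderate drop is expected in this assay, about at the edge of the scatter rather than far beyond it. The expected step is a 2.4-fold lower number from compound 1 to compound 3 (0.38 log units; beyond the scatter). Compound 3 is estimated at 8 nM, with a range from 2.5 nM to 30 nM.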

Compound 3, half-maximal effective concentration: 14.8 nM
Compound 3: middle estimate off by 1.9-fold (0.27 log units), on the low side; measured number inside the range.
By their numbers in this assay, from the lowest: compound 2; then compounds 3 and 1 (each within the scatter of the next).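

On the aromatic nitrogen, cycloheptyl in place of cyclopropylmethyl gives in this assay a 1.3-fold lower number from compound 1 to compound 3 (0.12 log units; within the scatter). Within the data shown here, this is the first single-place step at this position, and it shows that a seven-membered carbon ring can stand there with no difference from cyclopropylmethyl that can be told from the scatter. Going from 4 to 7 heavy atoms at this position therefore does not by itself bring a lower number in this pair. Nothing at hand bears on why this is so.

Steps to compound 2 cannot be read, since it differs from compound 1 and compound 3 in more than one place. Going by these compounds, what an open chain such as n-butyl, or a cycloheptyl ring carrying an amine, would give on this nitrogen remains open.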